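Carbamate chain growth on a shared core

A few compounds are considered here, and "the series" means these few. Any claim that something is new, unique, unknown or untested is made for them only; others in the source may bear on it.

Measured compounds:
compound 1 `CC(C)C(=O)OCOC(=O)N1CCN(C(=O)c2nc(Nc3cc(C4CC4)[nH]n3)c3cc(Cl)ccc3n2)C[C@H]1C`; in an assay for inhibition of serine/threonine-protein kinase PAK 4 (Homo sapiens), read by FRET and Z'-LYTE, with a stated time of 60 min, tested at 50 uM, in the presence of a further agent that is not named here (a higher number here means a stronger effect of the compound at the concentration tested, a lower number a weaker effect), compound 1 gives 86.9%
compound 2 `COC(=O)N1CCN(C(=O)c2nc(Nc3cc(C4CC4)[nH]n3)c3cc(Cl)ccc3n2)C[C@H]1C`; in this assay compound 2 gives 98.5%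
compound 3 `CCOC(=O)N1CCN(C(=O)c2nc(Nc3cc(C4CC4)[nH]n3)c3cc(Cl)ccc3n2)C[C@H]1C`; in this assay compound 3 gives 93.4%

Compound 3 stands second highest of the three numbers, with compound 2 nearest and compound 1 furthest, and both of its gaps lie within the scatter. The three compounds share one core and differ only on the saturated chain carbon bound to an oxygen next to a carbonyl group. The step of a number 11.6 percentage points higher from compound 1 to compound 2 (beyond the scatter) is modest and beyond the scatter; the steps of a number 6.5 percentage points higher from compound 1 to compound 3 (within the scatter) and a number 5.1 percentage points lower from compound 2 to compound 3 (within the scatter) are within it.

Compound 4 `CC(C)OC(=O)N1CCN(C(=O)c2nc(Nc3cc(C4CC4)[nH]n3)c3cc(Cl)ccc3n2)C[C@H]1C` is the next member: methyl in place of hydrogen on a saturated chain carbon bound to an oxygen next to a carbonyl group and a saturated chain carbon. The step that bears on it most directly is a number 5.1 percentage points lower from compound 2 to compound 3 (within the scatter), where the same kind of change, methyl in place of hydrogen on that chain carbon, moved the number within the scatter. Among the measured compounds shown here, nothing among the measured steps suggests a change beyond the scatter for a further methyl, so the expected step is a number 3.4 percentage points lower from compound 3 to compound 4 (within the scatter), and compound 4 is estimated at 90%, in the range 80% to 97%.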

Compound 4, a percentage reported as inhibition, at one concentration (the size of the read-out at that concentration, not a potency) in the serine/threonine-protein kinase PAK 4 assay: 91.2%
Estimate against measurement, compound 4: 1.2 percentage points below, within the range that was stated.
By their numbers in the serine/threonine-protein kinase PAK 4 assay, from the lowest: compounds 1, 4, 3 and 2 (each within the scatter of the next, the first and the last beyond it).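

In the serine/threonine-protein kinase PAK 4 assay compound 3 gives 93.4% and compound 4 gives 91.2%, so a further methyl on the saturated chain carbon bound to an oxygen next to a carbonyl group and a saturated chain carbon, turning ethoxycarbonyl into isopropoxycarbonyl, brings no resolvable change: a number 2.2 percentage points lower from compound 3 to compound 4 (within the scatter). Compound 4 also sits within the scatter of both ends of the series, with a number 7.3 percentage points lower from compound 2 to compound 4 (within the scatter) and a number 4.3 percentage points higher from compound 1 to compound 4 (within the scatter), so this branched carbamate cannot be placed apart from compound 1 or compound 2, even though those two differ beyond the scatter. In a physicochemical assay, read by HPLC, in phosphate buffer, with a stated time of 2 h, at pH 7.4 (a lower number here means that less of the compound is left, a higher number that more of the compound is left), compound 3 gives 97.7% and compound 4 gives 99%, and the same change gives a number 1.3 percentage points higher from compound 3 to compound 4 (within the scatter). No evidence is available that accounts for either result.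

Going by these compounds, what a tert-butyl group, a longer chain or a chain carrying an amine would do in place of isopropyl stays open. Readings at a single concentration also leave the potency of these compounds open.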